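N-methylation of the glycinamide side chain on two cores

The source may report more compounds than this note shows. Statements on the series, on what has been measured and on what is new or still open speak of the compounds shown alone.

Working notes on a small set measured in a functional assay on MCF7 cells (Homo sapiens) for antiproliferative activity, read by MTT assay, with a stated time of 48 h; on this read-out lower numbers stand for stronger inhibition and higher numbers for weaker inhibition.

Compound 1 `COc1ccc(C(=O)c2ccc(OC)c3c2C=CC(C)(C)O3)c(NC(=O)CN)c1` gives 1250 nM in this assay. Compound 2 `CNCC(=O)Nc1cc(OC)ccc1C(=O)c1ccc(OC)c2c1C=CC(C)(C)O2` differs from it by methyl in place of hydrogen on an amine nitrogen and gives 3040 nM in this assay; the step is a 2.4-fold higher number from compound 1 to compound 2 (0.39 log units; beyond the scatter).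

Compound 3 `C=C(c1ccc2c(c1)C=CC(C)(C)O2)c1ccc(OC)cc1NC(=O)CN` sits on a different core; the difference between the two cores is not broken down here. In this assay compound 3 gives 420 nM, the lowest of the three numbers measured, and its steps to compound 1 and to compound 2 both lie beyond the scatter.

Compound 4 `C=C(c1ccc2c(c1)C=CC(C)(C)O2)c1ccc(OC)cc1NC(=O)CNC` is not yet measured. Going by the values given here, it differs from compound 3 by methyl in place of hydrogen on an amine nitrogen, the same change, at the same place, as the one from compound 1 to compound 2. The expectation is that this change costs a comparable amount on the second core, because the matched step reads a 2.4-fold higher number from compound 1 to compound 2 (0.39 log units; beyond the scatter), so the estimated step from compound 3 is a 2.4-fold higher number from compound 3 to compound 4 (0.38 log units; beyond the scatter). The estimate for compound 4 in this assay is 1000 nM, with a range expected from 500 nM to 2200 nM.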

Compound 4, half-maximal inhibitory concentration: 720 nM
Compound 4: the middle estimate sits 1.4-fold (0.14 log units) above what was measured, within the range that was stated.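

Carried to the second core in this assay, methyl in place of hydrogen on the amine nitrogen gives a 1.7-fold higher number from compound 3 to compound 4 (0.23 log units; within the scatter), whereas on the core of compound 1 it gives a 2.4-fold higher number from compound 1 to compound 2 (0.39 log units; beyond the scatter), so only the first of these steps can be read as a real loss. Set side by side, the two steps cannot be told apart, and the series gives no sign that the change behaves differently on the two cores: the same change on two cores in this assay, a 2.4-fold higher number (0.39 log units; beyond the scatter) from compound 1 to compound 2 and a 1.7-fold higher number (0.23 log units; within the scatter) from compound 3 to compound 4, 1.4-fold (0.15 log units) apart, within the scatter of two such steps. This rests on a single pair per core, so it does not show that the step has a fixed size, that it carries to any further core, or why it has the size it has.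

The compounds shown leave open how a dimethylamino or ethylamino group would read at the same place on either core. They also leave open what a longer chain between the carbonyl and the amine would do in this assay.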